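Swapping Methoxy for Fluoro in Compound 1

The compounds below may be only part of what the source reports. "The series", "measured", "known", "first", "only" and "open" are said of these compounds alone.

Among the measured compounds shown here, in a functional assay on MCF7 cells (Homo sapiens) for antiproliferative activity, read by MTT assay, with a stated time of 48 h (a lower number here means a stronger inhibitor, a higher number a weaker inhibitor), compound 1 `COc1ccc(/C=C/C(=O)Nc2nnc(-c3ccc(C)cc3)s2)cc1` gives 0.35 ug/mL, the lowest of the three numbers measured so far. Compound 3 `COc1ccc(/C=C/C(=O)Nc2nnc(-c3ccccc3)s2)cc1` gives 0.83 ug/mL, and compound 2 `O=C(/C=C/c1ccccc1)Nc1nnc(-c2ccccc2)s1` gives 1.47 ug/mL. Compound 4 `Cc1ccc(-c2nnc(NC(=O)/C=C/c3ccc(F)cc3)s2)cc1` has not yet been measured. It differs from compound 1 in one place: fluoro in place of methoxy on an aromatic carbon. Thus the 4-methoxyphenyl of compound 1 becomes 4-fluorophenyl in compound 4.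

For the measured compounds named here, no measured compound carries fluoro, so the evidence is indirect. The nearest measured change is a 1.8-fold lower number from compound 2 to compound 3 (0.25 log units; within the scatter), where methoxy takes the place of hydrogen, and it lies within the scatter. The other measured change, a 2.4-fold higher number from compound 1 to compound 3 (0.38 log units; beyond the scatter), is modest and beyond the scatter, but it concerns the methyl, which compound 4 keeps. Only a small move toward a higher number therefore seems likely, and it may not clear the scatter. The expected change is a 1.7-fold higher number from compound 1 to compound 4 (0.23 log units; within the scatter). For compound 4, the estimated value is 0.6 ug/mL, with an expected range of 0.2 ug/mL to 1.6 ug/mL.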

Compound 4, half-maximal inhibitory concentration: 1.27 ug/mL
Beside the measured number, compound 4's estimate is 2.1-fold (0.33 log units) below it; low and high end bracket the measured number.
By their numbers in this assay, from the lowest: compound 1; then compounds 3, 4 and 2 (each within the scatter of the next).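

The 4-methoxyphenyl position is not indifferent to what it carries: in this assay, a 3.6-fold higher number from compound 1 to compound 4 (0.56 log units; beyond the scatter) marks a clear weakening with the methyl kept in place. Among the compounds shown here, the earlier compounds could not show this, since the only step at this position, a 1.8-fold lower number from compound 2 to compound 3 (0.25 log units; within the scatter) on a background without the methyl, stayed within the scatter and could not be told apart from no change. No measurement here accounts for the effect of exchanging methoxy for fluoro on this ring.

Still open, from the compounds shown here alone, is whether the weakening is peculiar to fluoro or follows any replacement of methoxy, which a hydroxyl, an amine or a longer ether chain such as ethoxy at this position would help to show. Also open, going by these compounds, is whether the same exchange would have a similar effect on a compound lacking the methyl.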